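Removing One Methyl From the Pyrazole Amide Substituent

A few compounds are considered here, and "the series" means these few. Any claim that something is new, unique, unknown or untested is made for them only; others in the source may bear on it.

Compound 1 `Cc1ccc(OCC(=O)N(Cc2cccs2)c2ccnn2C)cc1` gives 422 nM in an assay on HEK293 cells for agonist activity at transient receptor potential cation channel subfamily M member 8 (Homo sapiens), read by fluorescence and calcium flux, with a stated time of 15 min; a higher number here means that more compound is needed for the effect, a lower number that less compound is needed.
Compound 2 `Cc1ccc(OCC(=O)N(Cc2cccs2)C2COC2)cc1` gives 23000 nM in this assay.
Compound 3 `Cc1ccc(OCC(=O)N(Cc2cccs2)c2c(C)n[nH]c2C)cc1` gives 0.3 nM in this assay.

Compound 3 stands lowest of the three numbers, with the steps of a 1400-fold lower number from compound 1 to compound 3 (3.15 log units; beyond the scatter) and a 77000-fold lower number from compound 2 to compound 3 (4.88 log units; beyond the scatter) both large and well beyond the scatter. Compound 4 `Cc1ccc(OCC(=O)N(Cc2cccs2)c2c[nH]nc2C)cc1` differs from compound 3 by hydrogen in place of methyl on an aromatic carbon. Among the compounds with values here, no measured step removes a single methyl from this ring, so nothing here bears on the change directly. The two measured steps that alter the group on the amide-type nitrogen were both large, showing that this position is sensitive, so a moderate loss from compound 3 seems more likely than no change. For compound 4 the expected step is a 10-fold higher number from compound 3 to compound 4 (1.00 log units; beyond the scatter). Compound 4 is therefore estimated at 3 nM, with a range from 0.5 nM to 30 nM.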

Compound 4, half-maximal effective concentration: 0.4 nM
Beside the measured number, compound 4's estimate is 7.5-fold (0.88 log units) above it, outside the stated range (below it).
By their numbers in this assay, from the lowest: compounds 3 and 4 (each within the scatter of the next); then compound 1; then compound 2.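

In this assay the methyl on this aromatic carbon gives way to hydrogen with only a 1.3-fold higher number from compound 3 to compound 4 (0.12 log units; within the scatter) as the step, so compound 3 does not need this methyl for its low number. The large gaps to the other groups on the amide-type nitrogen remain with the 3-methyl-1H-pyrazol-4-yl group, at a 1100-fold lower number from compound 1 to compound 4 (3.02 log units; beyond the scatter) and a 58000-fold lower number from compound 2 to compound 4 (4.76 log units; beyond the scatter) for that change. No available measurement offers an explanation for this result. Still open, going by these compounds, is whether the remaining methyl can also give way to hydrogen. Also open, on these data alone, is how ethyl, chlorine or an amine would fare on the carbon that now carries hydrogen.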